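This account rests on a few compounds, and the source may have more. Where it says the series, first, only, none or still open, it means among the compounds named here.

Working notes on the series.

Compound 3 `Cc1ccc(CN2C(=O)S/C(=C\c3ccc(N)cc3)C2=O)cc1` carries a 4-methylphenyl on the saturated chain carbon bound to the amide-type nitrogen in the ring. In a functional assay on CCRF-CEM cells (Homo sapiens) for cytotoxicity, read by cell counting, with a stated time of 3 days (on this read-out lower numbers stand for stronger inhibition and higher numbers for weaker inhibition), compound 3 gives only a limit, > 250000 nM, and no number. Compound 1 `Nc1ccc(/C=C2\SC(=O)N(Cc3cccc(Cl)c3)C2=O)cc1`, which carries 3-chlorophenyl at the same place, gives 18000 nM in this assay. The step of an at least 13-fold higher number from compound 1 to compound 3 (1.14 log units; beyond the scatter) therefore runs toward weaker inhibition, with compound 3 sitting at the limit of > 250000 nM in this assay, at which 1 of the 3 values shown sits. Compound 2 `C=C(Br)C(=O)Nc1ccc(/C=C2\SC(=O)N(C)C2=O)cc1` gives 360 nM in this assay; no single-place step to compound 3 or compound 4 is shown for it.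

The change to compound 4 `CN1C(=O)S/C(=C\c2ccc(N)cc2)C1=O` is hydrogen in place of 4-methylphenyl on a saturated chain carbon bound to an amide-type nitrogen in a ring: the 4-methylphenyl leaves and a bare hydrogen remains. Within the data shown here, only the step from compound 1 to compound 3 bears on this position, and it shows that the two aryl groups at this carbon differ by a large margin. Removal of the aryl group altogether is not covered by any measured step, so the direction is open. Compound 4 is expected to move as an at least 5.0-fold lower number from compound 3 to compound 4 (0.69 log units; beyond the scatter), back toward a measurable number. The estimate for compound 4 in this assay is 50000 nM, within 8000 nM to 300000 nM.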

Compound 4, half-maximal inhibitory concentration: 62000 nM
The estimate for compound 4 lay 1.2-fold (0.09 log units) below the measured number, within the range that was stated.
By their numbers in this assay, from the lowest: compound 2; then compound 1; then compound 4. At a limit, above all of these: compound 3.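

At the saturated chain carbon bound to an amide-type nitrogen in a ring, hydrogen now gives a reference point for the two aryl groups in this assay: there is an at least 4.0-fold lower number from compound 3 to compound 4 (0.60 log units; beyond the scatter), and a 3.4-fold higher number from compound 1 to compound 4 (0.54 log units; beyond the scatter), so 4-methylphenyl and 3-chlorophenyl lie on opposite sides of hydrogen. The first of these steps rests on a limit and not on a number: the limit of > 250000 nM in this assay, at which 1 of the 4 values shown sits. At the nitrogen on the aromatic ring, hydrogen in place of (1-bromoethenyl)carbonyl gives a 170-fold higher number from compound 2 to compound 4 (2.24 log units; beyond the scatter), the largest measurable step shown.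

Still open, on these data alone, is whether the order at the chain carbon holds when (1-bromoethenyl)carbonyl sits on that nitrogen. Also open, as far as these compounds go, is how an unsubstituted phenyl, a pyridine ring or a longer alkyl chain would compare with hydrogen at the chain carbon.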